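Lactam replaces amide on the pendant ring of compound 3

A few compounds are considered here, and "the series" means these few. Any claim that something is new, unique, unknown or untested is made for them only; others in the source may bear on it.

Measured so far:
compound 1 `O=C(O)c1ccc2noc(-c3ccc(-c4cccnc4)cc3)c2c1` gives 54 nM in an assay for inhibition of inositol hexakisphosphate kinase 2 (Homo sapiens), read by colorimetric assay, coupled enzyme assay and malachite green, with a stated time of 120 min, in the presence of a further agent that is not named here; on this read-out higher numbers stand for weaker inhibition and lower numbers for stronger inhibition
compound 2 `O=C(O)c1ccc2noc(-c3ccc(-c4ccncc4)cc3)c2c1` gives 150 nM in this assay
compound 3 `CC(C)NC(=O)c1ccc(-c2onc3ccc(C(=O)O)cc23)cc1` gives 350 nM in this assay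

Compound 3 stands at the highest number of the three, that is, it is the weakest inhibitor of the set: the step of a 6.5-fold higher number from compound 1 to compound 3 (0.81 log units; beyond the scatter) and the step of a 2.3-fold higher number from compound 2 to compound 3 (0.37 log units; beyond the scatter) both lie beyond the scatter. Among the pendant groups, the step of a 2.8-fold higher number from compound 1 to compound 2 (0.44 log units; beyond the scatter) shows that moving the ring nitrogen already costs a modest amount, and exchanging either pyridyl for the isopropylcarbamoyl group costs more.

Compound 4 `O=C(O)c1ccc2noc(-c3ccc(N4CCCC4=O)cc3)c2c1` keeps the shared core and the pendant phenyl ring and carries the change (2-oxopyrrolidin-1-yl in place of isopropylcarbamoyl on an aromatic carbon); the group sits para to a large group. Going by the values given here, no measured pair exchanges an amide for a lactam, so the only guidance is that the three pendant groups tried span a modest range in this assay, with the non-aromatic carbamoyl at the weak end. The lactam keeps the carbonyl acceptor but loses the donor and closes a five-membered ring. On this basis the expected step of a 1.1-fold lower number from compound 3 to compound 4 (0.04 log units; within the scatter) is small, within or near the scatter, in no firm direction. Compound 4 is therefore estimated at 320 nM in this assay, with a range from 110 nM to 950 nM.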

Compound 4, half-maximal inhibitory concentration: 480 nM
Compound 4: the middle estimate sits 1.5-fold (0.18 log units) below what was measured; the range from low to high includes it.
By their numbers in this assay, from the lowest: compound 1; then compound 2; then compounds 3 and 4 (each within the scatter of the next).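

In this assay, closing the open amide into the lactam removes the amide hydrogen and adds a five-membered non-aromatic ring, yet a 1.4-fold higher number from compound 3 to compound 4 (0.14 log units; within the scatter) is all that this change gives at this position, para to a large group. The new compound also shows that the gap to the pyridyl compounds is not confined to the isopropylcarbamoyl group, with a 3.2-fold higher number from compound 2 to compound 4 (0.51 log units; beyond the scatter) on one side and an 8.9-fold higher number from compound 1 to compound 4 (0.95 log units; beyond the scatter) on the other, so both non-aromatic groups give higher numbers than either pyridyl group, and none of the four compounds goes against this. No measurement at hand accounts for these steps or for the small difference between the amide and the lactam.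

On these data alone, it remains open how a plain phenyl ring, a pyridin-2-yl ring or a dimethylcarbamoyl group would read at this position, and the last of these would separate loss of the amide hydrogen from ring closure. As far as these compounds go, a six-membered lactam and a replacement of the carboxylic acid on the shared core by a methyl ester or a tetrazole are also open.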